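Replacing diisopropylamino with 2-carboxypyrrolidin-1-yl on a shared core

The source may report more compounds than this note shows. Statements on the series, on what has been measured and on what is new or still open speak of the compounds shown alone.

Values so far in a functional assay on PC-3 cells (Homo sapiens) for inhibition, read by MTT assay, with a stated time of 48 h, tested at 10 uM (a higher number here means more inhibition of growth at the concentration tested, a lower number less inhibition of growth), are these
- compound 1 `CCN(CC)Cc1c(O)c([C@H]2CCN(C)C[C@H]2O)c2oc(C)cc(=O)c2c1O` gives 2%
- compound 2 `Cc1cc(=O)c2c(O)c(CN(C(C)C)C(C)C)c(O)c([C@H]3CCN(C)C[C@H]3O)c2o1` gives 0%

Compound 2 stands at 0% in this assay and compound 1 at 2% on the same scale, so the two lie within the scatter of each other and both show almost no inhibition of growth. The next step changes one group on the shared core to give compound 3 `Cc1cc(=O)c2c(O)c(CN3CCCC3C(=O)O)c(O)c([C@H]3CCN(C)C[C@H]3O)c2o1` and the difference reads 2-carboxypyrrolidin-1-yl in place of diisopropylamino on a saturated chain carbon bound to an aromatic carbon in full. Here 2-carboxypyrrolidin-1-yl stands in place of diisopropylamino on a saturated chain carbon bound to an aromatic carbon. Going by the values given here, the one measured step at this place, with diisopropylamino in place of diethylamino, was a number 2 percentage points lower from compound 1 to compound 2 (within the scatter) and it is the only guide. Among the compounds with values here, no measured compound carries a ring in this place, so that guide is thin. Starting from compound 2 at 0% and taking that one step as the guide, the expected change is a number 3 percentage points higher from compound 2 to compound 3 (within the scatter) and nothing beyond the scatter is expected. For compound 3 the expected value is 3% with an estimated range from 0% to 14% as the likely span.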

Compound 3, percent growth inhibition at one concentration: 0%
Estimate against measurement, compound 3: 3 percentage points above; the range from low to high includes it.
By their numbers in this assay, from the lowest: compounds 2, 3 and 1 (each within the scatter of the next).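

In this assay, 2-carboxypyrrolidin-1-yl on a saturated chain carbon bound to an aromatic carbon gives no change at the digits printed from compound 2 to compound 3 (within the scatter), and set against diethylamino at the same place it gives a number 2 percentage points lower from compound 1 to compound 3 (within the scatter). The earlier pair compared only two open-chain amines, whereas this change brings in a five-membered non-aromatic ring and a carboxylic acid, with its hydrogen-bond donor, and the compound still shows almost no inhibition of growth, like the two before it. No measurement in hand bears on why the readings stay together at this level.

With all three compounds this low, the series gives no ranking of the groups at this place, and it does not show whether any group here could lift the reading clear of the scatter on the shared core. Plain pyrrolidin-1-yl, which has the ring without the carboxylic acid, would separate those two features, while morpholin-4-yl or a longer chain such as dibutylamino would test whether this place can respond at all.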